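Replacing the trifluoromethyl benzamide in compound 3

The source may report more compounds than this note shows. Statements on the series, on what has been measured and on what is new or still open speak of the compounds shown alone.

In a functional assay on MCF7 cells (Homo sapiens) for inhibition, read by MTT assay (a lower number here means a stronger inhibitor, a higher number a weaker inhibitor), compound 3 (`COc1cc2ncnc(Nc3ccc(NC(=O)c4cccc(C(F)(F)F)c4)cc3)c2cc1OC`) gives > 100000 nM. This value is a limit of the assay and not a number, so any step from compound 3 has only one measured end.

Compound 4 (`COc1cc2ncnc(Nc3ccc(NC(=O)c4c(F)cccc4F)cc3)c2cc1OC`) places 2,6-difluorophenyl in place of 3-(trifluoromethyl)phenyl on a carbonyl carbon.

Going by the values given here, three measured steps bear on this change. Compound 1 (`COc1cc2ncnc(Nc3ccc(NC(=O)c4ccccc4C)cc3)c2cc1OC`) gives 21000 nM, and compound 2 (`COc1cc2ncnc(Nc3ccc(NC(=O)c4ccccc4F)cc3)c2cc1OC`) gives 11000 nM. These two differ by a 1.9-fold lower number from compound 1 to compound 2 (0.28 log units; within the scatter). The two steps into compound 3 are an at least 4.7-fold higher number from compound 1 to compound 3 (0.67 log units; beyond the scatter) and an at least 9.0-fold higher number from compound 2 to compound 3 (0.95 log units; beyond the scatter). Read in reverse, they suggest that leaving the 3-(trifluoromethyl)phenyl group should lower the number by a size at least comparable to theirs.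

Compound 2 is the nearest measured neighbour, since it also carries fluorine on this aromatic ring and gives 11000 nM. Among the compounds with values here, no measured compound has two fluorines on this ring, so the range stays wide and a second limit reading cannot be ruled out.

The expected step is an at least 5.8-fold lower number from compound 3 to compound 4 (0.76 log units; beyond the scatter), towards a lower number and beyond the scatter.

The estimated value for compound 4 is 17000 nM, with an expected range of 5000 nM to 60000 nM.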

Compound 4, half-maximal inhibitory concentration: 24000 nM
Beside the measured number, compound 4's estimate is 1.4-fold (0.15 log units) below it; the measured number falls inside the stated range.
By their numbers in this assay, from the lowest: compounds 2, 1 and 4 (each within the scatter of the next, the first and the last beyond it). At a limit, above all of these: compound 3.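

Replacing 3-(trifluoromethyl)phenyl with 2,6-difluorophenyl on this carbonyl carbon in this assay gives an at least 4.1-fold lower number from compound 3 to compound 4 (0.61 log units; beyond the scatter), so a ring carrying two fluorines returns the series to a measurable reading. The value of compound 3 is a limit of the assay and not a number, so this step has only one measured end: the limit of > 100000 nM in this assay, at which 1 of the 4 values shown sits. The second fluorine brings no gain over the single one, with a 2.2-fold higher number from compound 2 to compound 4 (0.34 log units; beyond the scatter), while a 1.1-fold higher number from compound 1 to compound 4 (0.06 log units; within the scatter) leaves 2,6-difluorophenyl and 2-methylphenyl within the scatter of each other.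

The compounds shown do not separate the effect of the trifluoromethyl group from that of its place on the ring, as no other compound here carries that group and none carries a single fluorine or a methyl group at the place it occupies in compound 3. From the compounds shown here alone, how an amine or a carboxylic acid on this aromatic ring would read in this assay also stays open.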